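The compounds below may be only part of what the source reports. "The series", "measured", "known", "first", "only" and "open" are said of these compounds alone.

Measured so far in a functional assay on LoVo cells (Homo sapiens) for inhibition, read by MTT assay, with a stated time of 48 h; on this read-out lower numbers stand for stronger inhibition and higher numbers for weaker inhibition:
Compound 1 `Cc1nc(N(C)c2ccc([Se]C#N)c(C)c2)c2ccccc2n1` gives 19 nM here
Compound 2 `Cc1nc(N(C)c2ccc([Se]C#N)c(Cl)c2)c2ccccc2n1` gives 12 nM here

These two numbers cannot be told apart, and compound 2 therefore holds no clear place of its own. Compound 3 `Cc1nc(N(C)c2ccc([Se]C#N)c(F)c2)c2ccccc2n1` has not yet been measured. Against compound 2 it carries fluoro in place of chloro on an aromatic carbon, counted as fluoro in place of chloro on an aromatic carbon in all. Among the compounds with values here, only one measured step bears on this swap: chloro in place of methyl on an aromatic carbon, which came to a 1.6-fold lower number from compound 1 to compound 2 (0.20 log units; within the scatter) and no more. That single step is thin evidence, but it gives no reason to expect a change beyond the scatter in this assay for compound 3. The expected step is a 1.3-fold higher number from compound 2 to compound 3 (0.12 log units; within the scatter) on this reasoning. Compound 3 is estimated at 16 nM with an expected range from 7 nM to 35 nM in this read-out.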

Compound 3, half-maximal inhibitory concentration: 13 nM
Compound 3: middle estimate off by 1.2-fold (0.09 log units), on the high side; low and high end bracket the measured number.
By their numbers in this assay, from the lowest: compounds 2, 3 and 1 (each within the scatter of the next).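

In this assay, the place ortho to a group of 3 heavy atoms and meta to a large group has now held methyl, chloro and fluoro, and the numbers do not separate them: a 1.1-fold higher number from compound 2 to compound 3 (0.03 log units; within the scatter) and a 1.5-fold lower number from compound 1 to compound 3 (0.16 log units; within the scatter) both lie within the scatter. The direct swap of one halogen for the other thus adds a second readable comparison to the single earlier step, and neither new step shows a change that can be told from repeat variation among these three compounds. Nothing measured here offers an explanation for this flat result.

The compounds shown leave open whether an amine, a carboxylic acid or a longer chain at this place would move the number beyond the scatter. As far as these compounds go, what a change elsewhere on the shared core would do also remains open.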